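This account rests on a few compounds, and the source may have more. Where it says the series, first, only, none or still open, it means among the compounds named here.

Measured so far in a physicochemical assay for lipophilicity, in phosphate buffer, measured as octanol-water partition, with a stated time of 24 h; a lower number here means a more polar compound, a higher number a more lipophilic compound:

Compound 1, `O=C(CSc1nc2ccccc2s1)N/N=C/c1ccc(Oc2ccccc2)cc1`: 5.6
Compound 2, `O=C(CSc1nc2ccccc2s1)N/N=C/c1ccc(Oc2ccc(Cl)cc2)cc1`: 5.6
Compound 3, `C(=N/Nc1nc2ccccc2s1)\c1ccc(Oc2ccccc2)cc1`: 5.2

Compound 1 and compound 2 share one core; compound 3 has a different core, and the difference between the two cores is not broken down here. Compound 3 sits lowest of the three numbers, and its gap to compound 1 is beyond the scatter. Between compound 1 and compound 2 the change is chloro in place of hydrogen on an aromatic carbon, and in this assay it gave no change at the digits printed from compound 1 to compound 2 (within the scatter).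

Compound 4, `Clc1ccc(Oc2ccc(/C=N/Nc3nc4ccccc4s3)cc2)cc1`, is not yet measured. It differs from compound 3 by chloro in place of hydrogen on an aromatic carbon, the same change as that from compound 1 to compound 2, at the same kind of place. On that one measured pair the step is expected to be small: compound 4 is estimated at 5.4, with a range from 5 to 5.9, a step of a number 0.20 log units higher from compound 3 to compound 4 (within the scatter), because the corresponding step of no change at the digits printed from compound 1 to compound 2 (within the scatter) lay within the scatter. Among the measured compounds shown here, only one such pair is known, so the expectation rests on a single precedent on a different core.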

Compound 4, partition coefficient: 5.6
Estimate against measurement, compound 4: 0.20 log units below; low and high end bracket the measured number.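

In this assay, chloro in place of hydrogen on an aromatic carbon gave a number 0.40 log units higher from compound 3 to compound 4 (beyond the scatter), whereas the same change on the other core gave no change at the digits printed from compound 1 to compound 2 (within the scatter), so in this series the step does not carry over from one core to the other as a fixed amount: it lies beyond the scatter on one core and within it on the other. With only these two pairs, this shows that the core can matter to the size of the step, but it does not establish a rule for any further core or for any other group. Nothing measured here explains why the two steps differ.

The compounds shown leave open how this assay would respond to other groups at the same place on the phenoxy ring, such as fluoro, methoxy, an amine or a carboxylic acid. They also leave open whether either core would give a similar step with chloro placed elsewhere on that ring.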